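The source may report more compounds than this note shows. Statements on the series, on what has been measured and on what is new or still open speak of the compounds shown alone.

Compound 1 `O=C(CCc1ccc(C(F)(F)F)cc1)Nc1ccc2nc(N3CCC3)ccc2c1`: 56 nM
Compound 2 `O=C(CCc1ccc(C(F)(F)F)cc1)Nc1ccc2nc(N3CC4CC3CO4)ccc2c1`: 70 nM
Compound 3 `O=C(CCc1ccc(C(F)(F)F)cc1)Nc1ccc2nc(N3CCC4(CCNC4)C3)ccc2c1`: 140 nM

All three were run in a functional assay on HEK293 cells for activation of melanin-concentrating hormone receptor 1 (Rattus norvegicus), read by inositol phosphate accumulation; a higher number here means that more compound is needed for the effect, a lower number that less compound is needed. Compound 1 has the lowest number of the three. Nearest is compound 2, reached by a 1.3-fold higher number from compound 1 to compound 2 (0.10 log units; within the scatter), within the scatter. Furthest is compound 3, reached by a 2.5-fold higher number from compound 1 to compound 3 (0.40 log units; beyond the scatter), modest but beyond the scatter. Between compound 2 and compound 3 the step is a 2.0-fold higher number from compound 2 to compound 3 (0.30 log units; within the scatter), within the scatter.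

Compound 4 `CCN(CC)c1ccc2cc(NC(=O)CCc3ccc(C(F)(F)F)cc3)ccc2n1` differs from compound 1 in one place: diethylamino in place of azetidin-1-yl on an aromatic carbon. The measured steps all change the same aromatic carbon, each putting a bicyclic group in place of azetidin-1-yl, and each gave a higher number, with only a 2.5-fold higher number from compound 1 to compound 3 (0.40 log units; beyond the scatter) beyond the scatter. Diethylamino carries no ring and stands closer in size to azetidin-1-yl than either bicyclic group, so nothing beyond the scatter is expected in this assay; if anything a slightly higher number, given a 1.3-fold higher number from compound 1 to compound 2 (0.10 log units; within the scatter) and a 2.5-fold higher number from compound 1 to compound 3 (0.40 log units; beyond the scatter) both pointed that way. The expected step is a 1.3-fold higher number from compound 1 to compound 4 (0.13 log units; within the scatter). Compound 4 is estimated at 75 nM, with a range from 30 nM to 190 nM.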

Compound 4, half-maximal effective concentration: 830 nM
Estimate against measurement, compound 4: 11-fold (1.04 log units) below, outside the stated range (above it).
By their numbers in this assay, from the lowest: compounds 1, 2 and 3 (each within the scatter of the next, the first and the last beyond it); then compound 4.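

Diethylamino in place of azetidin-1-yl on this aromatic carbon next to the ring nitrogen gives a 15-fold higher number from compound 1 to compound 4 (1.17 log units; beyond the scatter) in this assay, so this position tolerates some changes of the amine far less well than the earlier compounds suggested. Heavy-atom count does not order the series: the larger bicyclic groups also keep lower numbers, with a 12-fold higher number from compound 2 to compound 4 (1.07 log units; beyond the scatter) and a 5.9-fold higher number from compound 3 to compound 4 (0.77 log units; beyond the scatter) as the steps to the diethylamino compound. No measured evidence bears on the reason for these steps.

Among the compounds shown here, with only one ring-free group, the loss of a ring cannot be separated from the presence of the two ethyl chains. Dimethylamino, pyrrolidin-1-yl and piperidin-1-yl at the same carbon would be needed to tell these apart.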